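The source may report more compounds than this note shows. Statements on the series, on what has been measured and on what is new or still open speak of the compounds shown alone.

Among the measured compounds shown here, in a functional assay on a cell-free system (plasma, Homo sapiens), with a stated time of 3 min (on this read-out higher numbers stand for weaker inhibition and lower numbers for stronger inhibition), compound 1 (`O=C(NCc1cc(Cl)ccc1-n1cnnn1)[C@@H]1C[C@@H]2C[C@@H]2N1C(=O)[C@H](O)CC1CC1`) gives 1700 nM and stands highest of the two numbers measured so far. Compound 2 (`CC1(C[C@@H](O)C(=O)N2N=CC[C@H]2C(=O)NCc2cc(Cl)ccc2-n2cnnn2)CC1`) gives 730 nM in this assay and so lies lower, by a gap beyond the usual scatter. For the measured compounds named here, these two compounds differ in more than one place, so no measured step isolates a single change. Compound 3 (`O=C(NCc1cc(Cl)ccc1-n1cnnn1)[C@@H]1C[C@@H]2C[C@@H]2N1C(=O)[C@H](O)C1CCCCC1`) carries cyclohexyl in place of cyclopropylmethyl on a saturated chain carbon bound to a carbonyl carbon and an oxygen on a saturated carbon and otherwise keeps the core of compound 1. Going by the values given here, with no measured step as a guide, a modest move toward stronger inhibition is expected, estimated as a 2.4-fold lower number from compound 1 to compound 3 (0.39 log units; beyond the scatter) and only slightly beyond the scatter. Compound 3 is expected at 700 nM in this assay, with an estimated range from 180 nM to 2700 nM on this read-out.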

Compound 3, half-maximal inhibitory concentration: 600 nM
Compound 3: middle estimate off by 1.2-fold (0.07 log units), on the high side; the measured number falls inside the stated range.
By their numbers in this assay, from the lowest: compounds 3 and 2 (each within the scatter of the next); then compound 1.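

Among the compounds shown here, the change from cyclopropylmethyl to cyclohexyl gives the first single-change reading at this position, the saturated chain carbon bound to a carbonyl carbon and an oxygen on a saturated carbon: in this assay the step is a 2.8-fold lower number from compound 1 to compound 3 (0.45 log units; beyond the scatter). With the rest of compound 1 kept, inhibition therefore responds to the group carried here, and the larger cyclohexyl is accepted with a modest gain rather than a loss. Nothing available explains this gain.

This single step cannot separate the effect of ring size from that of the carbon count, and it leaves open whether cyclopentyl, phenyl or an open isobutyl chain would behave alike. It also leaves open whether cyclohexyl would bring a similar gain on the core of compound 2.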